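Amide substitution on the trimethoxyaniline series

A few compounds are considered here, and "the series" means these few. Any claim that something is new, unique, unknown or untested is made for them only; others in the source may bear on it.

Compound 1 `CCC/C=C/C(=O)N(Cc1ccc(OC)c(O)c1)c1cc(OC)c(OC)c(OC)c1` is the reference point of this small set. In a functional assay on HCT-116 cells (Homo sapiens) for inhibition, read by MTT assay, with a stated time of 48 h (a lower number here means a stronger inhibitor, a higher number a weaker inhibitor), compound 1 gives 95 nM, the lowest of the three numbers. Compound 3 `C/C=C/C(=O)N(Cc1ccc(OC)c(N)c1)c1cc(OC)c(OC)c(OC)c1` is the nearest to it and gives 300 nM in this assay, a gap that is beyond the usual scatter, so compound 1 stands as the stronger of that pair. Compound 2 `COC(=O)c1cc(CNc2cc(OC)c(OC)c(OC)c2)ccc1OC`, which carries no amide at all, is the furthest away and gives 38100 nM in this assay, far weaker than both of the amides. No two of the measured compounds differ in only one place, so no single step can be read directly from them.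

Compound 4 `COc1ccc(CN(C(=O)CBr)c2cc(OC)c(OC)c(OC)c2)cc1O` has not yet been measured. It differs from compound 1 at the amide carbonyl: bromomethyl in place of pent-1-en-1-yl on a carbonyl carbon. The two amides measured so far, compound 1 and compound 3, both sit in the low range in this assay, whereas compound 2 without the amide is much weaker, so the amide itself appears to carry most of the activity among these three. A shorter group on the carbonyl carbon is expected to cost a little, and the step from compound 1 to compound 4 is estimated at a 2.1-fold higher number from compound 1 to compound 4 (0.32 log units; beyond the scatter), close to the scatter. Compound 4 is therefore expected to give about 200 nM in this assay, plausibly between 40 nM and 1000 nM.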

Compound 4, half-maximal inhibitory concentration: 68 nM
Estimate against measurement, compound 4: 2.9-fold (0.47 log units) above; low and high end bracket the measured number.
By their numbers in this assay, from the lowest: compounds 4 and 1 (each within the scatter of the next); then compound 3; then compound 2.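

In this assay, the step at the amide carbonyl, bromomethyl in place of pent-1-en-1-yl on a carbonyl carbon, reads as a 1.4-fold lower number from compound 1 to compound 4 (0.15 log units; within the scatter), so the two compounds cannot be told apart in this assay. Within the data shown here, this is the first single-place comparison, and it shows that this position accepts a group of 2 heavy atoms with no double bond as readily as a chain of 5 heavy atoms with one, at least for this pair. No measured property or other supporting data accompanies the result, so nothing can be said about why the two groups read alike.

The step changes chain length, the double bond and the bromine together, so a group such as plain methyl, chloromethyl or a saturated pentyl chain on the carbonyl carbon would be needed to separate these contributions. Steps involving compound 2 and compound 3 cannot be read, as each differs from the others in more than one place, which leaves the contribution of the amide and of the ring substituents unresolved.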